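From Chloro to Amino on the Shared Core

The source may hold more compounds than are shown below. What is called first, only, known or untested is meant among the compounds shown, and "the series" means these compounds.

Values measured in a functional assay on HCT-116 cells (Homo sapiens) for antiproliferative activity, read by MTT assay, with a stated time of 48 h (a higher number here means a weaker inhibitor, a lower number a stronger inhibitor), are these
- Compound 1 `CCCCC(CCO)n1cnc2c(Cl)nc(Cl)nc21` gives 15500 nM
- Compound 2 `CCCCCCC(CCO)n1cnc2c(Cl)ncnc21` gives 11900 nM
- Compound 3 `CCCCCCC(CCO)n1cnc2c(Cl)nc(Cl)nc21` gives 12100 nM

Compound 3 cannot be told apart from the other two, as the step of a 1.0-fold higher number from compound 2 to compound 3 (0.01 log units; within the scatter) and the step of a 1.3-fold lower number from compound 1 to compound 3 (0.11 log units; within the scatter) both stay small. Compound 4 `CCCCCCC(CCO)n1cnc2c(N)nc(Cl)nc21`, not yet measured, has amino in place of chloro on an aromatic carbon in its structure. Neither measured step touches that carbon, and all three measured compounds carry chloro there, so the guide is weak. A modest move towards a weaker inhibitor is expected, and the estimated change is a 1.8-fold higher number from compound 3 to compound 4 (0.26 log units; within the scatter) in this assay with wide uncertainty. For compound 4 the estimated value is 22000 nM (expected range 9000 nM to 60000 nM).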

Compound 4, half-maximal inhibitory concentration: > 50000 nM
Compound 4: no number, only a limit; the forecaster's own chance of this, stated with the estimate: 15%; middle value at least 2.2-fold (0.35 log units) away from the limit.
By their numbers in this assay, from the lowest: compounds 2, 3 and 1 (each within the scatter of the next). At a limit, above all of these: compound 4.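

In this assay, replacing chloro with amino on this aromatic carbon gives an at least 4.1-fold higher number from compound 3 to compound 4 (0.61 log units; beyond the scatter). Going by these compounds alone, the earlier steps, on the chain and at another aromatic carbon, stayed within the scatter, so this is the first change that clearly separates two compounds. On these data alone, compound 4 has only a limit, not a number, so the full size of this step stays unknown: the limit of > 50000 nM in this assay, at which 1 of the 4 values shown sits.

As far as these compounds go, it remains open how a methylamino or methoxy group on this carbon would compare with chloro and amino. The same swap on compound 2, which has no second chloro group, is also untested here.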